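A few compounds are considered here, and "the series" means these few. Any claim that something is new, unique, unknown or untested is made for them only; others in the source may bear on it.

Three compounds share one core and differ only in the group on a carbonyl carbon: compound 1 `COC(=O)c1cc(-c2cccc(NC(=O)c3ccc(/C=C/C(=O)c4ccccc4OC)cc3)c2)on1`, compound 2 `COC(=O)c1cc(-c2cccc(NC(=O)c3ccc(/C=C/C(=O)c4cccc(Br)c4)cc3)c2)on1` and compound 3 `COC(=O)c1cc(-c2cccc(NC(=O)c3ccc(/C=C/C(=O)c4ccc(F)cc4F)cc3)c2)on1`. In an ADME assay on Vero cells (Chlorocebus sabaeus) for cytotoxicity, read by MTT assay, with a stated time of 72 h (on this read-out higher numbers stand for lower toxicity in this test and lower numbers for higher toxicity in this test), compound 1 gives only a limit of the assay, > 40 ug/mL. In this assay compound 2 likewise reaches a limit, > 100 ug/mL. In this assay compound 3 also stops at a limit, > 40 ug/mL. All three values are limits, so the steps a step that the two limits leave unreadable from compound 1 to compound 2, a step that the two limits leave unreadable from compound 1 to compound 3 and a step that the two limits leave unreadable from compound 2 to compound 3 cannot be given a size; the values sit at the limit of > 40 ug/mL in this assay, at which 2 of the 3 values shown sit, and (the limit of > 100 ug/mL in this assay, at which 1 of the 3 values shown sits). Compound 3 thus stands at a limit rather than at a number, beside two neighbours that do the same. Compound 4 `COC(=O)c1cc(-c2cccc(NC(=O)c3ccc(/C=C/C(=O)c4ccc(CC(C)C)cc4)cc3)c2)on1` differs from compound 3 by 4-isobutylphenyl in place of 2,4-difluorophenyl on a carbonyl carbon. For the measured compounds named here, no measured step gives a size to lean on for such a change. The step that the limit leaves unreadable from compound 3 to compound 4 is therefore expected to be small, with the read-out most likely a limit again. Compound 4 is expected to give about 60 ug/mL in this assay, between 25 ug/mL and 150 ug/mL.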

Compound 4, half-maximal cytotoxic concentration: > 10 ug/mL
Compound 4 was reported as a limit; the forecaster's own chance of this, stated with the estimate: 75%; the middle value is on the limit's open side.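

For the compounds shown here, compound 4 gives only a limit, > 10 ug/mL, and compound 1, compound 2 and compound 3 also stop at limits, so no step to compound 4 can be read. The compounds shown leave open whether changing the group on the carbonyl carbon alters the read-out in this assay at all, and by how much.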